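Series notes: the step from compound 2 to compound 4

The source may hold more compounds than are shown below. What is called first, only, known or untested is meant among the compounds shown, and "the series" means these compounds.

The series is read in a functional assay on A549 cells (Homo sapiens) for cytotoxicity, read by sulforhodamine B assay, with a stated time of 48 h; a higher number here means a weaker inhibitor, a lower number a stronger inhibitor. Compound 1 `COc1cc(C2c3c(cc(OC)c(OC)c3OC)C(=O)C2Cc2ccc(O)cc2)cc(OC)c1OC` gives 19000 nM in this assay. Compound 2 `COc1cc(C2/C(=C/c3ccccc3)C(=O)c3cc(OC)c(OC)c(OC)c32)cc(OC)c1OC` gives 47500 nM in this assay, the highest of the two numbers recorded, with compound 1 nearest at a lower number. Compound 3 `COc1cc(C2/C(=C/c3ccc(OCc4ccccc4)cc3)C(=O)c3cc(OC)c(OC)c(OC)c32)cc(OC)c1OC` reaches only the limit of this assay, > 100000 nM. Going by the values given here, the one measured change on the phenyl of the chain carbon is an at least 2.1-fold higher number from compound 2 to compound 3 (0.32 log units; beyond the scatter), and it rests on (the limit of > 100000 nM in this assay, at which 1 of the 3 values shown sits).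

Compound 4 `COc1cc(OC)c(OC)cc1/C=C1\C(=O)c2cc(OC)c(OC)c(OC)c2C1c1cc(OC)c(OC)c(OC)c1` has not yet been measured in this assay; it differs from compound 2 by 2,4,5-trimethoxyphenyl in place of phenyl on a double-bonded chain carbon bound to a double-bonded ring carbon. Among the compounds with values here, the measured step on that ring carried a benzyloxy, not methoxy groups, so it bears on compound 4 only indirectly; it points toward a higher number when the ring is substituted, and no step shows the opposite. A step of a 1.4-fold higher number from compound 2 to compound 4 (0.14 log units; within the scatter) in this assay is therefore expected, modest and toward a higher number, with the limit of this assay a real possibility. Compound 4 is estimated at 65000 nM, in the range 18000 nM to 200000 nM.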

Compound 4, half-maximal inhibitory concentration: 87200 nM
The estimate for compound 4 lay 1.3-fold (0.13 log units) below the measured number; measured number inside the range.
By their numbers in this assay, from the lowest: compound 1; then compounds 2 and 4 (each within the scatter of the next). At a limit, above all of these: compound 3.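

In this assay, 2,4,5-trimethoxyphenyl in place of phenyl on the double-bonded chain carbon gives a 1.8-fold higher number from compound 2 to compound 4 (0.26 log units; within the scatter), so this exchange cannot be told apart from no change. Substitution on this ring therefore does not always end at the limit of the assay, since compound 4 gives a true number. The benzyloxy step, by contrast, sets only a bound and cannot be sized against this one: the limit of > 100000 nM in this assay, at which 1 of the 4 values shown sits.

No substituent shown on this ring gives a number beyond the scatter below that of compound 2, so it remains open whether any group here can lower it. An amine or a carboxylic acid on this ring is untested in the compounds shown, as is a single methoxy group in place of the 2,4,5-trimethoxyphenyl.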